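Moving the chlorine: 2-chlorophenyl to 3-chlorophenyl

The compounds below may be only part of what the source reports. "The series", "measured", "known", "first", "only" and "open" are said of these compounds alone.

In a functional assay on U-373MG ATCC cells (Homo sapiens) for inhibition, read by MTT assay, with a stated time of 72 h (on this read-out higher numbers stand for weaker inhibition and lower numbers for stronger inhibition), compound 1 `CC1(C)CC(NC(=O)Nc2ccccc2Cl)c2cc(F)ccc2O1` gives 40000 nM and holds the higher of the two measured numbers, while compound 2 `CC1(C)CC(NC(=O)Nc2ccccc2Cl)c2cc(Cl)ccc2O1` gives 17000 nM on the same scale. Compound 3 `CC1(C)CC(NC(=O)Nc2cccc(Cl)c2)c2cc(F)ccc2O1` differs from compound 1 by 3-chlorophenyl in place of 2-chlorophenyl on an amide-type nitrogen with 3-chlorophenyl in place of 2-chlorophenyl on an amide-type nitrogen. Among the compounds with values here, the only measured step is a 2.4-fold lower number from compound 1 to compound 2 (0.37 log units; beyond the scatter) for chloro in place of fluoro on an aromatic carbon, a modest change at another place, so no measured step tests this swap. No change beyond the scatter is therefore expected in this assay in either direction. The estimated step is a 1.1-fold lower number from compound 1 to compound 3 (0.06 log units; within the scatter) and no larger. Compound 3 is estimated at 35000 nM (range 14000 nM to 90000 nM).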

Compound 3, half-maximal inhibitory concentration: 39000 nM
The estimate for compound 3 lay 1.1-fold (0.05 log units) below the measured number, within the range that was stated.
By their numbers in this assay, from the lowest: compound 2; then compounds 3 and 1 (each within the scatter of the next).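

The swap of 3-chlorophenyl for 2-chlorophenyl on the amide-type nitrogen gives a 1.0-fold lower number from compound 1 to compound 3 (0.01 log units; within the scatter) in this assay, so on the core of compound 1 this change leaves the read-out within the scatter. Within the data shown here, the earlier step concerned only chloro in place of fluoro on an aromatic carbon, and this is the first measured step at this position. Nothing available explains this result. The compounds shown leave open whether an unsubstituted phenyl or a pyridine on this nitrogen would shift the number. They also leave open whether the same swap would read alike on the core of compound 2.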